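The compounds below may be only part of what the source reports. "The series", "measured", "known", "first", "only" and "open" are said of these compounds alone.

Among the compounds with values here, compound 3, with structure `Oc1cccc(-c2cc(-c3ccccc3F)cc(-c3cccc(O)c3)n2)c1`, is the one member of this set that gives a number in a functional assay on HeLa cells (Homo sapiens) for inhibition; on this read-out higher numbers stand for weaker inhibition and lower numbers for stronger inhibition: compound 3 gives 16000 nM. Compound 1, with structure `Oc1cccc(-c2cc(-c3cccc(F)c3)cc(-c3ccccc3O)n2)c1`, gives only a limit of this assay, > 50000 nM. Compound 2, with structure `Oc1ccc(-c2cc(-c3cccc(F)c3)cc(-c3ccccc3O)n2)cc1`, likewise gives only a limit, > 50000 nM. The step from compound 1 to compound 2 is a step that the two limits leave unreadable from compound 1 to compound 2, and the change behind it is 4-hydroxyphenyl in place of 3-hydroxyphenyl on an aromatic carbon. How the core of compound 1 and the core of compound 3 differ is not broken down here. Compound 4, with structure `Oc1ccc(-c2cc(-c3ccccc3F)cc(-c3cccc(O)c3)n2)cc1`, has not yet been measured; it differs from compound 3 by 4-hydroxyphenyl in place of 3-hydroxyphenyl on an aromatic carbon. This is the same kind of change as that from compound 1 to compound 2, though around the place the neighbours differ: meta to a 2-fluorophenyl group and meta to a 3-hydroxyphenyl group in compound 4, meta to a 2-hydroxyphenyl group and meta to a 3-fluorophenyl group in compound 2. Because of the limit of > 50000 nM in this assay, at which 2 of the 3 values shown sit, the measured step gives no size to lean on. For compound 4 the step of a 1.6-fold higher number from compound 3 to compound 4 (0.19 log units; within the scatter) is expected, set close to no change from compound 3. Compound 4 is thus estimated at 25000 nM in this assay, between 8000 nM and 80000 nM.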

Compound 4, half-maximal inhibitory concentration: 14300 nM
For compound 4 the middle estimate is 1.7-fold (0.24 log units) above the measured one; measured number inside the range.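

In this assay putting 4-hydroxyphenyl in place of 3-hydroxyphenyl gives a 1.1-fold lower number from compound 3 to compound 4 (0.05 log units; within the scatter) and so, on this core, the swap makes no difference that can be told apart from the scatter of repeated measurements. This is a single readable pair on a single core, so it describes that core and sets no rule for the whole series. Whether the change behaves alike on the core of compound 1 stays unknown, because the step from compound 1 to compound 2 cannot be read and both of its values are limits rather than numbers: the limit of > 50000 nM in this assay, at which 2 of the 4 values shown sit.

The compounds shown leave open whether an amine or a carboxylic acid in place of the hydroxyl on these phenyl groups would move the read-out beyond the scatter. Also open, going by these compounds, is how the same swap behaves on a further core where both partners give a number instead of a limit.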